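Carbamoyl to Ethyl(methyl)carbamoyl on a Shared Piperazine Urea

The source may hold more compounds than are shown below. What is called first, only, known or untested is meant among the compounds shown, and "the series" means these compounds.

Compound 1 `CCN(C)C(=O)N1CCN(C(=S)SCc2cn(Cc3ccc(F)cc3)nn2)CC1`: 23700 nM
Compound 2 `Cc1ccc(Cn2cc(CSC(=S)N3CCN(C(N)=O)CC3)nn2)cc1`: > 128000 nM
Compound 3 `COc1ccc(Cn2cc(CSC(=S)N3CCN(C(N)=O)CC3)nn2)cc1`: > 128000 nM

In a functional assay on SMMC-7721 cells (Homo sapiens) for cytotoxicity, read by MTT assay, with a stated time of 72 h (a lower number here means a stronger inhibitor, a higher number a weaker inhibitor), compound 3 reaches only a limit of the assay, > 128000 nM. Compound 2 likewise stops at a limit, > 128000 nM. Among the compounds with values here, the one measured step, a step that the two limits leave unreadable from compound 2 to compound 3, is therefore unreadable, as the limit of > 128000 nM in this assay, at which 2 of the 3 values shown sit, shows. Compound 4 `CCN(C)C(=O)N1CCN(C(=S)SCc2cn(Cc3ccc(OC)cc3)nn2)CC1` carries ethyl(methyl)amino in place of amino on a carbonyl carbon. Within the data shown here, no measured step touches that carbonyl carbon, so none bears on it directly; compound 1, which carries the same ethyl(methyl)carbamoyl group, gives 23700 nM in this assay. Compound 4 is expected to sit near 40000 nM, within 15000 nM to 128000 nM. That estimate implies a step of an at least 3.2-fold lower number from compound 3 to compound 4 (0.50 log units; beyond the scatter), though a limit remains possible.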

Compound 4, half-maximal inhibitory concentration: > 128000 nM
Compound 4: only a limit was reported; the forecaster's own chance of this, stated with the estimate: 35%; middle value at least 3.2-fold (0.50 log units) from the limit.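

Keeping the ethyl(methyl)carbamoyl group fixed, the change from fluoro to methoxy gives an at least 5.4-fold higher number from compound 1 to compound 4 (0.73 log units; beyond the scatter) in this assay. So the ethyl(methyl)carbamoyl group does not by itself bring compound 4 to a readable value. The steps among compounds 2, 3 and 4 cannot be read, and this includes the change from carbamoyl to ethyl(methyl)carbamoyl, because all three stop at one limit: the limit of > 128000 nM in this assay, at which 3 of the 4 values shown sit.

As far as these compounds go, what carbamoyl does when fluoro sits on the aromatic carbon stays open. So does how a chloro group there, or a longer chain on the carbonyl carbon's nitrogen, would read.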